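Swapping chloro for bromo on the sulfonyl analogue

The source may hold more compounds than are shown below. What is called first, only, known or untested is meant among the compounds shown, and "the series" means these compounds.

Compound 1 `CN(C(=O)c1ccc(Cl)cc1)c1ccc2[nH]c(-c3n[nH]c4ccccc34)cc2n1` gives 450 nM in a functional assay on HL-60 cells (Homo sapiens) for antiproliferative activity, read by MTT assay, with a stated time of 72 h; a lower number here means a stronger inhibitor, a higher number a weaker inhibitor.
Compound 2 `CN(C(=O)c1ccc(Br)cc1)c1ccc2[nH]c(-c3n[nH]c4ccccc34)cc2n1` gives 1080 nM in this assay.
Compound 3 `CN(c1ccc2[nH]c(-c3n[nH]c4ccccc34)cc2n1)S(=O)(=O)c1ccc(Cl)cc1` gives 770 nM in this assay.

Compound 3 stands second highest of the three numbers. Its nearest neighbour is compound 2, with a 1.4-fold lower number from compound 2 to compound 3 (0.15 log units; within the scatter), and its furthest is compound 1, with a 1.7-fold higher number from compound 1 to compound 3 (0.23 log units; within the scatter); both of these gaps stay within the scatter, so the three compounds cannot be ordered with confidence.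

Compound 4 `CN(c1ccc2[nH]c(-c3n[nH]c4ccccc34)cc2n1)S(=O)(=O)c1ccc(Br)cc1` has not yet been measured. It differs from compound 3 in one place: bromo in place of chloro on an aromatic carbon. The same exchange has already been made once among the measured compounds, on the carbonyl pair, where it gave a 2.4-fold higher number from compound 1 to compound 2 (0.38 log units; beyond the scatter). Among the measured compounds shown here, that step is the only direct guide, and it points to a modestly higher number when bromo replaces chloro on this aromatic carbon. Transferring it to the sulfonyl pair assumes that the effect does not depend on the linker, which the data can neither confirm nor refute.

Compound 4 is therefore expected to show a somewhat weaker effect than compound 3, an estimated 2.1-fold higher number from compound 3 to compound 4 (0.32 log units; beyond the scatter). The estimate for compound 4 in this assay is 1600 nM, with a range from 700 nM to 3600 nM.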

Compound 4, half-maximal inhibitory concentration: 6240 nM
Estimate against measurement, compound 4: 3.9-fold (0.59 log units) below, outside the stated range (above it).
By their numbers in this assay, from the lowest: compounds 1, 3 and 2 (each within the scatter of the next, the first and the last beyond it); then compound 4.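

In this assay compound 4 is the weakest of the four, with an 8.1-fold higher number from compound 3 to compound 4 (0.91 log units; beyond the scatter) for the halogen exchange alone and a 14-fold higher number from compound 1 to compound 4 (1.14 log units; beyond the scatter) as the largest gap in the set. Sulfonyl in place of carbonyl gives a 1.7-fold higher number from compound 1 to compound 3 (0.23 log units; within the scatter) on the chloro compounds, too small to read as a real change, yet it gives a 5.8-fold higher number from compound 2 to compound 4 (0.76 log units; beyond the scatter) on the bromo compounds, so in these four compounds the effect of the linker cannot be read apart from the halogen. Bromo in place of chloro on this aromatic carbon is therefore no fixed increment, and its size differs between the carbonyl and sulfonyl linkers: the same change on two cores in this assay, a 2.4-fold higher number (0.38 log units; beyond the scatter) from compound 1 to compound 2 and an 8.1-fold higher number (0.91 log units; beyond the scatter) from compound 3 to compound 4, 3.4-fold (0.53 log units) apart, beyond the scatter of two such steps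

With only chloro and bromo shown at this place, it stays open how fluoro, methoxy or an amine on the same ring would read on either linker. These four numbers also leave open why the bromo compound on the sulfonyl linker stands so far from the other three, as they hold no measurement that would explain it.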